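Swapping methoxy for hydroxy on a pyrazole urea

The compounds below may be only part of what the source reports. "The series", "measured", "known", "first", "only" and "open" are said of these compounds alone.

Of the compounds shown here, three sharing one core have been tested in a functional assay on OVCAR-3 cells (Homo sapiens) for inhibition, read by sulforhodamine B assay, with a stated time of 48 h; on this read-out lower numbers stand for stronger inhibition of growth and higher numbers for weaker inhibition of growth. Compound 1 `O=C(Nc1cccc(-n2cc(-c3ccncc3)c(-c3ccc(Cl)c(O)c3)n2)c1)Nc1cccc(C(F)(F)F)c1` gives 1060 nM in this assay. Compound 2 `O=C(Nc1cccc(-n2cc(-c3ccncc3)c(-c3ccc(Cl)c(O)c3)n2)c1)Nc1ccc(Cl)c(Cl)c1` gives 1050 nM. Compound 3 `COc1cc(-c2nn(-c3cccc(NC(=O)Nc4ccc(Cl)c(C(F)(F)F)c4)c3)cc2-c2ccncc2)ccc1Cl` gives 889 nM, the lowest of the three numbers, though its gaps to compound 2 and to compound 1 both lie within the scatter. For the measured compounds named here, the only step between two measured compounds that differ in one place is a 1.0-fold lower number from compound 1 to compound 2 (0.00 log units; within the scatter), a change on the urea end of the molecule that left the number unchanged.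

Compound 4 `O=C(Nc1cccc(-n2cc(-c3ccncc3)c(-c3ccc(Cl)c(O)c3)n2)c1)Nc1ccc(Cl)c(C(F)(F)F)c1` differs from compound 3 by hydrogen in place of methyl on an oxygen on an aromatic ring. Going by the values given here, no measured pair isolates this change, so it has no direct precedent here. What the three numbers do show is that the urea end tolerates variation without moving the read-out, and that compounds with hydroxy and with methoxy on the chlorophenyl ring sit together within the scatter. Compound 4 is therefore expected to stay close to its neighbours, with a step of a 1.1-fold higher number from compound 3 to compound 4 (0.05 log units; within the scatter) estimated. The estimate for compound 4 is 1000 nM, within a range from 500 nM to 2000 nM.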

Compound 4, concentration for 50% growth inhibition: 830 nM
Compound 4: the middle estimate sits 1.2-fold (0.08 log units) above what was measured; the measured number falls inside the stated range.
By their numbers in this assay, from the lowest: compounds 4, 3, 2 and 1 (each within the scatter of the next).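

In this assay, hydrogen in place of methyl on the oxygen gives a 1.1-fold lower number from compound 3 to compound 4 (0.03 log units; within the scatter), so methoxy and hydroxy can now be compared directly, and the read-out does not separate them. Compound 4 also links this pair to the earlier hydroxy compounds through the urea end: trifluoromethyl in place of chloro gives a 1.3-fold lower number from compound 2 to compound 4 (0.10 log units; within the scatter), and chloro in place of hydrogen gives a 1.3-fold lower number from compound 1 to compound 4 (0.11 log units; within the scatter). All four compounds are now joined by single changes, and every one of these new steps stays within the scatter.

Still open, going by these compounds, is whether a longer chain on this oxygen, such as ethyl or propyl, or an amine in place of the hydroxy, would move the number. Nothing available here explains how little these changes alter the read-out.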